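Second methyl for fluoro in a bis-sulfonamide series

The source may hold more compounds than are shown below. What is called first, only, known or untested is meant among the compounds shown, and "the series" means these compounds.

Measured compounds in an assay for binding affinity to protein lin-28 homolog A (Mus musculus), with a stated time of 1 h; on this read-out lower numbers stand for stronger inhibition and higher numbers for weaker inhibition:
- compound 1, `O=S(=O)(Nc1ccccc1NS(=O)(=O)c1ccccc1)c1ccccc1`, 32200 nM
- compound 2, `Cc1ccc(NS(=O)(=O)c2ccc(F)cc2)c(NS(=O)(=O)c2ccc(F)cc2)c1`, 16200 nM
- compound 3, `Cc1ccc(S(=O)(=O)Nc2ccc(C)cc2NS(=O)(=O)c2ccc(F)cc2)cc1`, 11700 nM

Compound 3 and compound 2 give numbers that lie within the usual scatter of each other, whereas the number for compound 1 stands apart from that of compound 3 by more than the scatter. Within the data shown here, the step of a 1.4-fold lower number from compound 2 to compound 3 (0.14 log units; within the scatter) is the only measured step that bears on the next one, since compound 4, `Cc1ccc(S(=O)(=O)Nc2ccc(C)cc2NS(=O)(=O)c2ccc(C)cc2)cc1`, differs from compound 3 by the same kind of exchange: methyl in place of fluoro on an aromatic carbon. That earlier step stayed within the scatter, and there is nothing among the three measured compounds to suggest that the same exchange on the other ring would behave differently. A small move toward a lower number, if any, is therefore expected in this assay, but one that need not exceed the scatter. Compound 4 is expected to give about 9000 nM, within a range from 4500 nM to 18000 nM, which corresponds to an estimated step of a 1.3-fold lower number from compound 3 to compound 4 (0.11 log units; within the scatter).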

Compound 4, half-maximal inhibitory concentration: 14100 nM
Compound 4: middle estimate off by 1.6-fold (0.19 log units), on the low side; measured number inside the range.
By their numbers in this assay, from the lowest: compounds 3, 4, 2 and 1 (each within the scatter of the next, the first and the last beyond it).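

In this assay, the exchange of 4-fluorophenyl for 4-methylphenyl gives a 1.2-fold higher number from compound 3 to compound 4 (0.08 log units; within the scatter) on the remaining fluorinated group, and the same exchange gave a 1.4-fold lower number from compound 2 to compound 3 (0.14 log units; within the scatter) on the first. The exchange has therefore now been read on both groups, and neither step goes beyond the scatter, so in this assay the choice between fluoro and methyl at this place does not separate these compounds. No measurement is at hand that would account for these small steps.

The compounds shown leave open how this place, para to a large group, would respond to an amine, a carboxylic acid or a longer chain in place of the methyl. They also leave open whether any such group would give a step beyond the scatter.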